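Swapping the halogenated phenol for a nitrophenol

The compounds below may be only part of what the source reports. "The series", "measured", "known", "first", "only" and "open" are said of these compounds alone.

Within the data shown here, in a functional assay on DU-145 cells (Homo sapiens) for inhibition, read by trypan blue exclusion, with a stated time of 96 h (a lower number here means a stronger inhibitor of growth, a higher number a weaker inhibitor of growth), compound 1 `O=C(O)c1ccc(C(=O)/C(=C\c2ccc(O)c(Br)c2)SCc2ccc(Br)cc2)cc1` gives 25000 nM, the only actual number recorded in this set. For compound 2 `CSc1ccc(/C=C(/SCc2ccc(C)cc2)C(=O)c2ccc(Br)cc2)cc1` this assay reports only a limit, > 100000 nM. Among the measured compounds shown here, compound 2 differs from compound 1 in several places at once, so the two readings show only that compound 1 yields a measurable value while compound 2 does not. For the measured compounds named here, compound 1 therefore stands as the sole numerical reference, with the limit of > 100000 nM in this assay, at which 1 of the 2 values shown sits, the only other reading.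

Compound 3 `O=C(O)c1ccc(C(=O)/C(=C\c2ccc([N+](=O)[O-])c(O)c2)SCc2ccc(Br)cc2)cc1` is derived from compound 1 by the change (3-hydroxy-4-nitrophenyl in place of 3-bromo-4-hydroxyphenyl on a double-bonded chain carbon bound to a double-bonded chain carbon). Going by the values given here, no measured pair isolates this change, so any expectation rests on compound 1 alone. The estimated step of a 1.4-fold higher number from compound 1 to compound 3 (0.15 log units; within the scatter) is expected to be small, at most around the usual scatter of this assay, leaning toward somewhat weaker growth inhibition. Compound 3 is accordingly estimated at 35000 nM, within a range of 12000 nM to 100000 nM.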

Compound 3, concentration for 50% growth inhibition: 10000 nM
Beside the measured number, compound 3's estimate is 3.5-fold (0.54 log units) above it; measured number below the stated range.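

In this assay, among these compounds, placing 3-hydroxy-4-nitrophenyl where 3-bromo-4-hydroxyphenyl stood gives a 2.5-fold lower number from compound 1 to compound 3 (0.40 log units; beyond the scatter), the first comparison in this set in which only one place differs. It shows that growth inhibition responds to the group at this position, and that a nitro-bearing phenyl is accepted there in place of the bromine-bearing one, with the number moving in the stronger direction. The bromine gives way to a nitro group and the hydroxy group's position in the name also changes, and nothing measured here separates these two changes or accounts for the step.

Going by these compounds, whether an amine or a carboxylic acid in place of the nitro group would give a similar number remains open. Among the compounds shown here, compound 2 gives > 100000 nM, a limit and not a number, and no step to it can be read.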